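The source may report more compounds than this note shows. Statements on the series, on what has been measured and on what is new or still open speak of the compounds shown alone.

Compound 1 `Cc1ccc(-c2ccc(C3(C)CC(S(=O)(=O)c4ccc(F)cc4)=C(c4ccc(/C(N)=N\O)cc4)O3)cc2)cc1`: 13700 nM
Compound 2 `CC1(Cc2ccccc2)CC(S(=O)(=O)c2c(F)cccc2F)=C(c2ccc(/C(N)=N\O)cc2)O1`: 91400 nM
Compound 3 `CC1(Cc2ccccc2)CC(S(=O)(=O)c2ccc(F)cc2F)=C(c2ccc(/C(N)=N\O)cc2)O1`: 90600 nM

In an ADME assay on HepG2 cells (Homo sapiens) for cytotoxicity, read by MTT assay, with a stated time of 72 h (a higher number here means that more compound is tolerated, a lower number that less compound is tolerated), compound 1 stands at the lowest of the three numbers, so less of it is tolerated than of compound 2 or compound 3, both of which lie beyond the scatter above it. For the measured compounds named here, the only step between measured compounds, a 1.0-fold lower number from compound 2 to compound 3 (0.00 log units; within the scatter), concerns the aryl ring on the sulfonyl sulfur and does not touch the change considered here. Compound 4 `CC1(c2ccc(-c3ccncc3)cc2)CC(S(=O)(=O)c2ccc(F)cc2)=C(c2ccc(/C(N)=N\O)cc2)O1` differs from compound 1 by pyridin-4-yl in place of 4-methylphenyl on an aromatic carbon. Going by the values given here, no measured pair shows what this change does in this assay, so compound 4 is expected to stay close to compound 1, with wide uncertainty. The step of a 1.5-fold higher number from compound 1 to compound 4 (0.16 log units; within the scatter) is therefore the expected outcome. Compound 4 is estimated at 20000 nM, between 7000 nM and 60000 nM.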

Compound 4, half-maximal cytotoxic concentration: 30300 nM
For compound 4 the middle estimate is 1.5-fold (0.18 log units) below the measured one, and the stated range covers the measured number.
By their numbers in this assay, from the lowest: compound 1; then compound 4; then compounds 3 and 2 (each within the scatter of the next).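

In this assay, for the compounds shown here, pyridin-4-yl in place of 4-methylphenyl on an aromatic carbon, para to a large group, gives a 2.2-fold higher number from compound 1 to compound 4 (0.34 log units; beyond the scatter) and so provides the first measured reading of a change at this position. The step is modest but lies beyond the scatter, so exchanging this terminal ring does shift the number. Nothing measured here accounts for the step. The compounds shown leave open whether an amine or a carboxylic acid at this place would move the number further, and whether the step would hold with another aryl group on the sulfonyl sulfur.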